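The source may report more compounds than this note shows. Statements on the series, on what has been measured and on what is new or still open speak of the compounds shown alone.

Compound 1 `Cc1csc(NC(=O)Cn2cc(-c3ccccc3Cl)nn2)n1` was measured in a functional assay on BMDM cells (Mus musculus, strain C57BL/6) for inhibition, with a stated time of 2 days (on this read-out higher numbers stand for weaker inhibition and lower numbers for stronger inhibition), and gives 1240 nM. Among the values recorded so far, that is the only one that is an actual number. The other recorded value is the limit of > 30000 nM in this assay, at which 1 of the 2 values shown sits. Compound 2 `O=C(Cn1cc(-c2ccc(F)cc2)nn1)Nc1nc2ccccc2s1` reaches only > 30000 nM in this assay, which is a limit of the assay rather than a number. Compound 3 `Cc1csc(NC(=O)Cn2cc(-c3cccc(N)c3)nn2)n1` has not yet been measured. It differs from compound 1 in one place: 3-aminophenyl in place of 2-chlorophenyl on an aromatic carbon. Among the compounds with values here, no measured pair of compounds that differ in a single place exists here, so the size of this kind of step cannot be read off from measured compounds. The step is nonetheless expected to be a 2.8-fold higher number from compound 1 to compound 3 (0.45 log units; beyond the scatter), beyond the usual scatter and toward weaker inhibition. Compound 3 is accordingly estimated to give 3500 nM in this assay, with a plausible range from 900 nM to 15000 nM.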

Compound 3, half-maximal inhibitory concentration: 250 nM
Compound 3: middle estimate off by 14-fold (1.15 log units), on the high side, outside the stated range (below it).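

On the aromatic carbon of the five-membered aromatic ring with 3 nitrogen, the attached phenyl group can be changed without losing activity: in this assay, 3-aminophenyl in place of 2-chlorophenyl gives a 5.0-fold lower number from compound 1 to compound 3 (0.70 log units; beyond the scatter), toward stronger inhibition. This pair shows that the 2-chlorophenyl group is not required on this core, and that a phenyl group bearing an amine, with its hydrogen-bond donor and acceptor, is accepted here. Nothing measured here explains this step.

The step changes both the substituent and its place on the phenyl ring, so the effect of each remains unresolved; 2-aminophenyl and 3-chlorophenyl would help to separate them. Going by these compounds, whether the amine itself matters also stays open, a question that 3-hydroxyphenyl or 3-methoxyphenyl at the same carbon could address.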